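Estimating Compound 4 after a Linker Change

This account rests on a few compounds, and the source may have more. Where it says the series, first, only, none or still open, it means among the compounds named here.

Of the compounds shown here, three have been measured in a functional assay on OVCAR-3 cells (Homo sapiens) for inhibition, read by sulforhodamine B assay, with a stated time of 48 h; on this read-out higher numbers stand for weaker inhibition of growth and lower numbers for stronger inhibition of growth. Compound 1 `COc1cc(-c2nn(-c3cccc(NC(=O)c4ccc(Cl)c(C(F)(F)F)c4)c3)cc2-c2ccncc2)ccc1Cl` gives 2420 nM, compound 2 `COc1cc(-c2nn(-c3cccc(NC(=O)c4cccc(C(F)(F)F)c4)c3)cc2-c2ccncc2)ccc1Cl` gives 1200 nM, and compound 3 `O=C(Nc1cccc(-n2cc(-c3ccncc3)c(-c3ccc(Cl)c(O)c3)n2)c1)Nc1cc(C(F)(F)F)cc(C(F)(F)F)c1` gives 395 nM. On these numbers compound 2 stands second highest of the three: the step of a 2.0-fold lower number from compound 1 to compound 2 (0.30 log units; within the scatter) stays within the scatter, whereas the gap from compound 2 to compound 3 lies beyond it. The unmeasured compound 4 `COc1cc(-c2nn(-c3cccc(NC(=O)Nc4cccc(C(F)(F)F)c4)c3)cc2-c2ccncc2)ccc1Cl` differs from compound 2 in one place: (3-(trifluoromethyl)phenyl)amino in place of 3-(trifluoromethyl)phenyl on a carbonyl carbon. Going by the values given here, no measured step follows exactly this change. Among the compounds with values here, the only single-place step available concerns a different position on the molecule and was small, so it carries little weight here. Compound 3 shows a lower number than compound 2, yet it differs from compound 4 in more than one place, so its value serves only as a loose hint. For compound 4 a moderate drop in the number is expected, a 2.0-fold lower number from compound 2 to compound 4 (0.30 log units; within the scatter), in this assay. The estimate for compound 4 is 600 nM, with a range from 200 nM to 2000 nM.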

Compound 4, concentration for 50% growth inhibition: 579 nM
For compound 4 the middle estimate is 1.0-fold (0.02 log units) above the measured one; the measured number falls inside the stated range.
By their numbers in this assay, from the lowest: compounds 3 and 4 (each within the scatter of the next); then compounds 2 and 1 (each within the scatter of the next).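

In this assay the change from 3-(trifluoromethyl)phenyl to (3-(trifluoromethyl)phenyl)amino on the carbonyl carbon gives a 2.1-fold lower number from compound 2 to compound 4 (0.32 log units; beyond the scatter) and so, unlike the earlier chloro step, moves the number beyond the scatter, though only modestly. The entering group adds one nitrogen and one hydrogen-bond donor, and replacing 4-chloro-3-(trifluoromethyl)phenyl with the same group gives a 4.2-fold lower number from compound 1 to compound 4 (0.62 log units; beyond the scatter) as a larger but still modest step. No measured evidence is available to explain either step.

The compounds shown leave open whether the nitrogen itself matters or whether another one-atom link would serve equally well. An oxygen at that place, as in a carbamate, or a methylene group in its stead would help separate these possibilities.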